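Swapping the Aryl Ketone Substituent on a Pyrazole Chalcone

The source may report more compounds than this note shows. Statements on the series, on what has been measured and on what is new or still open speak of the compounds shown alone.

The measured compounds and their values:
compound 1 `COc1cc(-c2cc(/C=C/C(=O)c3ccc(N)cc3)[nH]n2)cc(OC)c1OC` gives 102%
compound 2 `COc1ccc(-c2cc(/C=C/C(=O)c3ccc(OC)c(OC)c3)[nH]n2)cc1` gives 89%
compound 3 `COc1cc(-c2cc(/C=C/C(=O)c3ccc(Cl)c(Cl)c3)[nH]n2)cc(OC)c1OC` gives 95%

These three compounds were tested in a functional assay on Malme-3M cells (Homo sapiens) for cytotoxicity, read by sulforhodamine B assay, with a stated time of 48 h, tested at 0.1 uM; a higher number here means a weaker effect of the compound at the concentration tested, a lower number a stronger effect. On the numbers shown, compound 3 stands second highest of the three; its nearest neighbour is compound 2 and its furthest is compound 1, and both gaps lie within the scatter, so no order among them can be read.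

Compound 4 `COc1ccc(C(=O)/C=C/c2cc(-c3cc(OC)c(OC)c(OC)c3)n[nH]2)cc1` is not yet measured. It differs from compound 3 in one place: 4-methoxyphenyl in place of 3,4-dichlorophenyl on a carbonyl carbon.

For the measured compounds named here, only one measured step changes the same place, the step from compound 1 to compound 3, which gave a number 7 percentage points lower from compound 1 to compound 3 (within the scatter). Compound 2 also carries a different group on the carbonyl carbon, but it differs from compound 3 in a second place too, so its value is noted only as it stands. With a single comparable step that itself stayed within the scatter, no step beyond the scatter is expected in this assay for compound 4, and the expected step is a number 1 percentage points lower from compound 3 to compound 4 (within the scatter).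

Compound 4 is therefore estimated at 94%, with a range from 80% to 106%.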

Compound 4, a percentage reported as activity, at one concentration (the size of the read-out at that concentration, not a potency): 91%
Compound 4: the middle estimate sits 3 percentage points above what was measured, and the stated range covers the measured number.
By their numbers in this assay, from the lowest: compounds 2, 4, 3 and 1 (each within the scatter of the next, the first and the last beyond it).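

In this assay, the group on the carbonyl carbon now gives a step beyond the scatter: methoxy in place of amino on an aromatic carbon gives a number 11 percentage points lower from compound 1 to compound 4 (beyond the scatter) in a modest change. By contrast, 4-methoxyphenyl in place of 3,4-dichlorophenyl gives a number 4 percentage points lower from compound 3 to compound 4 (within the scatter) and so sets no order between these two groups, even though the chlorine atoms leave and one oxygen enters. Nothing available explains why the amino-to-methoxy change moves the number.

On these data alone, it remains open whether this step would hold on a core with a different set of methoxy groups, as in compound 2. As far as these compounds go, it is also open how a carboxylic acid or a dimethylamino group in place of the methoxy on this aromatic ring would read in this assay at this concentration.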